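Isomeric swap of the chloropyrimidine in compound 3

A few compounds are considered here, and "the series" means these few. Any claim that something is new, unique, unknown or untested is made for them only; others in the source may bear on it.

Three compounds of this series have a number in a physicochemical assay for lipophilicity, read by HPLC, in phosphate buffer, measured as octanol-water partition, with a stated time of 24 h, at pH 7.4; a lower number here means a more polar compound, a higher number a more lipophilic compound. Compound 1 `Clc1ccc2c(NCCCNc3nccc(N4CCCC4)n3)ccnc2c1` gives 0.756 in this assay. Compound 2 `Clc1ccc2c(NCCCCNc3nccc(Cl)n3)ccnc2c1` gives 0.742 in this assay. Compound 3 `Clc1ccc2c(NCCNc3ccnc(Cl)n3)ccnc2c1` gives 0.489 in this assay. The three numbers lie close together: the gap from compound 3 to compound 2 and the gap from compound 3 to compound 1 both fall within the usual scatter of repeated measurements, so no order among the three can be read from these numbers, and compound 3 is best described as sitting among them.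

Compound 4 `Clc1ccc2c(NCCNc3nccc(Cl)n3)ccnc2c1` has not yet been measured in this assay. It differs from compound 3 in one place only: 4-chloropyrimidin-2-yl in place of 2-chloropyrimidin-4-yl on an amine nitrogen. The two compounds are built from the same atoms, joined differently, and the change keeps the count of donors and acceptors unchanged.

Going by the values given here, no measured pair shows a step of this kind, so the expectation rests on the structural change alone. The atoms are the same and only their arrangement differs. The expected step is a number 0.06 log units higher from compound 3 to compound 4 (within the scatter), small, in either direction, and not beyond the scatter. For compound 4 a value of 0.55 in this assay is expected, with a range from 0.15 to 0.95.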

Compound 4, distribution coefficient: 0.501
Beside the measured number, compound 4's estimate is 0.05 log units above it; the measured number falls inside the stated range.
By their numbers in this assay, from the lowest: compounds 3, 4, 2 and 1 (each within the scatter of the next).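

Notes on the chloropyrimidine isomers: in this assay, placing 4-chloropyrimidin-2-yl in place of 2-chloropyrimidin-4-yl on an amine nitrogen gives a number 0.01 log units higher from compound 3 to compound 4 (within the scatter), and this is the first step in the series that isolates a single place. For this one pair, the two isomeric groups, which have the same heavy atoms and the same donor and acceptor counts, cannot be told apart by this read-out, so the way the chloropyrimidine is joined at this place has no measurable consequence here. No supporting measurement is available that could account for the size of this step.

The compounds shown leave open whether the two isomeric groups would remain indistinguishable on a longer chain, such as a hexyl linker, since this single pair says nothing about other chain lengths. They also leave open whether a group of a different kind on the pyrimidine in place of the chlorine, such as a morpholine or a carboxylic acid, would produce a step beyond the scatter in this assay.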